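The source may report more compounds than this note shows. Statements on the series, on what has been measured and on what is new or still open speak of the compounds shown alone.

Going by the values given here, compound 1 `COc1cc(/C=C/C(=O)c2cc3cc(O)ccc3oc2=O)cc(OC)c1OC` is the only compound of the series with a number in a functional assay on K562 cells (Homo sapiens) for cytotoxicity, read by MTT assay, with a stated time of 72 h; a higher number here means a weaker inhibitor, a lower number a stronger inhibitor: in this assay compound 1 gives 8800 nM. Compound 2 `COc1cccc(COc2ccc3cc(C(=O)/C=C/c4ccccc4)c(=O)oc3c2)c1` stands at the limit of > 100000 nM in this assay, at which 1 of the 2 values shown sits, and in this assay compound 2 returns > 100000 nM, a limit rather than a number. Compound 3 `COc1cc(/C=C/C(=O)c2cc3cc(OCc4ccccc4)ccc3oc2=O)cc(OC)c1OC` has not yet been measured in this assay; it differs from compound 1 by benzyl in place of hydrogen on an oxygen on an aromatic ring. Among the compounds with values here, no step between measured compounds is available. A step towards weaker inhibition, beyond the usual scatter, is expected: a 3.4-fold higher number from compound 1 to compound 3 (0.53 log units; beyond the scatter). Compound 3 is expected to give about 30000 nM, within a range from 8000 nM to 100000 nM.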

Compound 3, half-maximal inhibitory concentration: 66400 nM
For compound 3 the middle estimate is 2.2-fold (0.35 log units) below the measured one; the measured number falls inside the stated range.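

In this assay, hydroxy to benzyloxy on this oxygen gives a 7.5-fold higher number from compound 1 to compound 3 (0.88 log units; beyond the scatter), so the position is sensitive to this change. Compound 3 still returns a number rather than a limit, so activity weakens without being lost within the range of this assay. Nothing measured for these compounds accounts for the size of the step. Open, from the compounds shown here alone, is whether the loss tracks the size of the group on this oxygen: a methyl group or an ethyl chain would test this, and a carboxylic acid or an amine at the end of such a chain would show whether other end groups read differently.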